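Adding a Chloro Group to Compound 1

The source may hold more compounds than are shown below. What is called first, only, known or untested is meant among the compounds shown, and "the series" means these compounds.

Of the compounds shown here, three sharing one core have been tested in a functional assay on the whole organism with Rattus norvegicus as the target, at a dose of 20 mg/kg by the intraperitoneal route; on this read-out higher numbers stand for more inhibition at the one dose given (going by the name of the read-out) and lower numbers for less inhibition. Compound 1, `Nc1nc(N)nc(-c2ccccc2Br)n1`, gives 26%. Compound 2, `Nc1nc(N)nc(-c2cc(F)ccc2Cl)n1`, gives 78%, and compound 3, `Nc1nc(N)nc(-c2cccc(F)c2)n1`, gives 70%. Compound 1 stands lowest of the three, with compound 3 nearer to it and compound 2 further away, both gaps beyond the usual scatter.

Among the measured compounds a single pair differs in just one place. Compound 3 turns into compound 2 by the change (chloro in place of hydrogen on an aromatic carbon), and this brings a number 8 percentage points higher from compound 3 to compound 2 (within the scatter), a step that lies within the scatter of repeated measurements. How the core of compound 1 differs from that of compound 3 is not broken down here.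

Compound 4, `Nc1nc(N)nc(-c2ccc(Cl)cc2Br)n1`, has not yet been measured. It arises from compound 1 by chloro in place of hydrogen on an aromatic carbon. Among the measured compounds shown here, this is the same kind of change as the one from compound 3 to compound 2, but the surroundings differ: in compound 4 the entering chloro sits meta to a bromo group and para to a group of 8 heavy atoms, while in compound 2 it sits ortho to a group of 8 heavy atoms and para to a fluoro group. For the measured compounds named here, the only recorded example of this kind of change moved the read-out by a number 8 percentage points higher from compound 3 to compound 2 (within the scatter). On that basis, in this assay the expected step is a number 12 percentage points higher from compound 1 to compound 4 (beyond the scatter), a modest rise that allows for the different surroundings. Compound 4 is therefore estimated to give 38% in this assay, with a likely range from 15% to 65%.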

Compound 4, a percentage reported as inhibition, in the whole organism at one dose (the size of the read-out at that dose, not a potency): 96%
Compound 4: the middle estimate sits 58 percentage points below what was measured; measured number above the stated range.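

In this assay, chloro in place of hydrogen on an aromatic carbon of the core of compound 1 brings a number 70 percentage points higher from compound 1 to compound 4 (beyond the scatter). So this change does not carry over from one core to another in this series with a fixed size, and a step recorded on one core proved a poor guide to the step on the other: the same change on two cores in this assay, a number 8 percentage points higher (within the scatter) from compound 3 to compound 2 and a number 70 percentage points higher (beyond the scatter) from compound 1 to compound 4, 62 percentage points apart, beyond the scatter of two such steps. What this does not show is why the two steps differ: two pairs cannot separate the part played by the rest of the core from the part played by the place where chloro enters, which in compound 4 is meta to a bromo group and para to a group of 8 heavy atoms, and they cannot tell what a third core would do.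

The compounds shown leave open whether another group in that same place, such as a methyl group, a methoxy group or an amine, would bring a similarly large rise on the core of compound 1, or whether such a rise is particular to chloro. They also leave open how compound 4 compares with compound 1 across a range of doses, as a reading at one dose gives a size of effect and not a potency.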